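Acetylation of the Core Amine in an Antiproliferative Series

The compounds below may be only part of what the source reports. "The series", "measured", "known", "first", "only" and "open" are said of these compounds alone.

Three compounds share a common core and differ in the group carried on the amide nitrogen of the pendant ring. Compound 1 `Nc1cccc2c(-c3cccc(NC(=O)c4ccc5c(c4)OCCO5)c3)ccnc12` gives 11400 nM in a functional assay on UACC-257 cells (Homo sapiens) for antiproliferative activity, read by sulforhodamine B assay, with a stated time of 48 h; a higher number here means a weaker inhibitor, a lower number a stronger inhibitor. Compound 2 `Nc1cccc2c(-c3cccc(NC(=O)c4nccs4)c3)ccnc12` gives 24300 nM in this assay, and the step of a 2.1-fold higher number from compound 1 to compound 2 (0.33 log units; beyond the scatter) is modest. Compound 3 `Nc1cccc2c(-c3cccc(NC(=O)Nc4cc(C(F)(F)F)cc(C(F)(F)F)c4)c3)ccnc12`, which carries a urea to a bis(trifluoromethyl)phenyl group, gives 1000 nM in this assay; this is the lowest of the three numbers, with compound 1 nearest and compound 2 furthest away, both gaps beyond the scatter.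

Compound 4 `CC(=O)Nc1cccc2c(-c3cccc(NC(=O)Nc4cc(C(F)(F)F)cc(C(F)(F)F)c4)c3)ccnc12` differs from compound 3 in one place: acetyl in place of hydrogen on a nitrogen on an aromatic ring. For the measured compounds named here, the change sits on the core rather than on the amide end, and no measured step touches that nitrogen. Going by the values given here, the single step available, the swap from compound 1 to compound 2, concerns the acyl group on the other side of the molecule and gives no guidance here. With nothing in the series that speaks to this change, compound 4 is expected to stay close to compound 3, with a step of a 1.3-fold higher number from compound 3 to compound 4 (0.11 log units; within the scatter) that is not expected to reach beyond the scatter. Compound 4 is therefore estimated at 1300 nM in this assay, within a range from 400 nM to 4500 nM.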

Compound 4, half-maximal inhibitory concentration: 14100 nM
Estimate against measurement, compound 4: 11-fold (1.04 log units) below, and the stated range ends below it.
By their numbers in this assay, from the lowest: compound 3; then compounds 1, 4 and 2 (each within the scatter of the next, the first and the last beyond it).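

The nitrogen on the shared core proves sensitive to substitution: amino to acetamido gives a 14-fold higher number from compound 3 to compound 4 (1.15 log units; beyond the scatter) in this assay, a large step. The only earlier step, a 2.1-fold higher number from compound 1 to compound 2 (0.33 log units; beyond the scatter), was modest and concerned the acyl group at the other end of the molecule, so the series had shown nothing about this nitrogen until now. With the urea to the bis(trifluoromethyl)phenyl group held constant, the free amino group goes with the lower number, but nothing shown accounts for the size of this step.

The compounds shown leave open whether the loss belongs to the acetyl group in particular or to any group placed on this nitrogen, such as a methyl group, a longer acyl chain like propionyl, or a methanesulfonyl group. They also leave open whether acetyl on the same nitrogen would give a step of similar size in the amide compounds, since the change is seen here only in the urea pair.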